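Urea-side aryl swap from compound 1 to compound 4

The compounds below may be only part of what the source reports. "The series", "measured", "known", "first", "only" and "open" are said of these compounds alone.

Compound 1 `COc1cc(NC(=O)Nc2cc(Nc3ccc(C(C)(C)C)cc3)ncn2)cc(OC)c1` gives 47.7% in a functional assay on NCI-H226 cells (Homo sapiens) for inhibition, read by MTT assay, with a stated time of 48 h, tested at 10 uM; on this read-out lower numbers stand for less inhibition and higher numbers for more inhibition at the one concentration tested (going by the name of the read-out). Compound 3 `COc1cc(NC(=O)Nc2cc(Nc3cc(F)ccc3OC)ncn2)cc(OC)c1` gives 37.7% in this assay; the two cores differ by 4-(tert-butyl)phenyl in place of 5-fluoro-2-methoxyphenyl on a nitrogen on an aromatic ring. Compound 2 `COc1ccc(F)cc1Nc1cc(NC(=O)Nc2c(Cl)cccc2Cl)ncn1` gives 31.3% in this assay. The change from compound 3 to compound 2 is 2,6-dichlorophenyl in place of 3,5-dimethoxyphenyl on an amide-type nitrogen, and it made a step of a number 6.4 percentage points lower from compound 3 to compound 2 (within the scatter).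

Compound 4 `CC(C)(C)c1ccc(Nc2cc(NC(=O)Nc3c(Cl)cccc3Cl)ncn2)cc1` is not yet measured. It differs from compound 1 by 2,6-dichlorophenyl in place of 3,5-dimethoxyphenyl on an amide-type nitrogen, the same change as from compound 3 to compound 2, at the same place. Among the compounds with values here, the step from compound 1 to compound 4 in this assay is therefore expected to resemble the earlier one, resting only on the single measured pair; the expectation is a number 6.7 percentage points lower from compound 1 to compound 4 (within the scatter). Compound 4 is estimated at 41%, with a likely span from 28% to 54%.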

Compound 4, a percentage reported as inhibition, at one concentration (the size of the read-out at that concentration, not a potency): 40%
Compound 4: the middle estimate sits 1 percentage points above what was measured, and the stated range covers the measured number.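

In this assay, 2,6-dichlorophenyl in place of 3,5-dimethoxyphenyl on an amide-type nitrogen gives a number 7.7 percentage points lower from compound 1 to compound 4 (within the scatter). Set beside the earlier step, the change carries over between the two cores at a similar size: the same change on two cores in this assay, a number 6.4 percentage points lower (within the scatter) from compound 3 to compound 2 and a number 7.7 percentage points lower (within the scatter) from compound 1 to compound 4, 1.3 percentage points apart, within the scatter of two such steps. Within the data shown here, both steps lie within the scatter, so the pair shows only that the swap reads alike on these two cores; it does not show that the swap itself moves the read-out, or that the agreement extends to any further core.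

Open, going by these compounds, is how a group other than these two aryl groups, such as an amine or a carboxylic acid, would read on that amide-type nitrogen. On these data alone, with one concentration per compound, potency also remains open.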